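A Change of Chain on the Aromatic Nitrogen of Compound 2

This account rests on a few compounds, and the source may have more. Where it says the series, first, only, none or still open, it means among the compounds named here.

Measured so far:
Compound 1, `CCCCCc1ccc2nc(N)sc2c1`, 7.5 mg/kg
Compound 2, `C=CCn1c(=N)sc2cc(OC(F)(F)F)ccc21`, 7 mg/kg

Of the compounds shown here, two have been tested in a functional assay on the whole organism with Rattus norvegicus as the target; on this read-out lower numbers stand for an effect already at smaller amounts and higher numbers for an effect only at larger amounts of compound. Compound 1 gives 7.5 mg/kg. Compound 2 gives 7 mg/kg, which is the lowest of the two numbers, although the gap to compound 1 lies within the scatter, so the two compounds cannot be told apart on this read-out. Among the measured compounds shown here, the two differ in several places at once, so no single step between them is defined.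

Compound 3, `CS(=O)(=O)CCn1c(=N)sc2cc(OC(F)(F)F)ccc21`, is not yet measured. Its structure differs from compound 2 in one place: (methylsulfonyl)methyl in place of vinyl on a saturated chain carbon bound to an aromatic nitrogen. For the measured compounds named here, nothing among the measured pairs shows what a change of this kind does in this assay, so the expectation rests only on the fact that the shared core is kept and that the two measured compounds give similar numbers. The step from compound 2 to compound 3 is therefore expected to be a 1.3-fold higher number from compound 2 to compound 3 (0.11 log units; within the scatter), with no clear direction beyond the scatter. Compound 3 is estimated at 9 mg/kg, with a range from 3 mg/kg to 30 mg/kg.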

Compound 3, dose for half-maximal effect: 1.8 mg/kg
Compound 3: the middle estimate sits 5.0-fold (0.70 log units) above what was measured; the whole stated range lies above it.
By their numbers in this assay, from the lowest: compound 3; then compounds 2 and 1 (each within the scatter of the next).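

Among the compounds shown here, the change from allyl to 2-(methylsulfonyl)ethyl on the aromatic nitrogen gives in this assay a 3.9-fold lower number from compound 2 to compound 3 (0.59 log units; beyond the scatter) and so provides the first step in this study that can be read at a single position. The earlier compounds shown here could not show this, as they differ in several places at once and cannot be told apart on this read-out. The step shows that this place accepts a chain ending in methylsulfonyl, with five heavy atoms entering where two leave and two hydrogen-bond acceptors where the vinyl end had none, and that the number then falls rather than rises, though no measurement at hand gives a reason for the fall.

The compounds shown leave open whether the methylsulfonyl group itself matters or whether other chains at this place would give a similar step, as a 2-methoxyethyl chain, a 2-(dimethylamino)ethyl chain or a plain propyl chain could tell. They also leave open whether the step would hold with a group other than trifluoromethoxy on the shared core, such as a chlorine atom.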